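This account rests on a few compounds, and the source may have more. Where it says the series, first, only, none or still open, it means among the compounds named here.

Measured compounds:
- compound 1 `O=C(O)[C@@H]1CCCN1C(=O)CN(c1nc(Cl)nc2[nH]cnc12)C1CC1`: 34.9%
- compound 2 `N=C(N)NCCC[C@H](NC(=O)CN(c1nc(Cl)nc2[nH]cnc12)C1CC1)C(=O)OCc1ccccc1`: 30.6%
- compound 3 `C[C@@H](O)[C@H](NC(=O)CN(c1nc(Cl)nc2[nH]cnc12)C1CC1)C(=O)O`: 30.1%

All three carry the shared core of compound 1 with an amide-linked acid or ester side chain. In a functional assay on the whole organism (Tail, strain ICR) with Mus musculus as the target, in the tail flick test, with a stated time of 60 min, at a dose of 25 umol/kg by the oral route (a higher number here means a stronger effect of the compound at the dose given, a lower number a weaker effect), compound 3 gives the lowest of the three numbers, but the separation is small: compound 2 lies within the scatter of it, and compound 1 as well, so no order among the three can be claimed. For the measured compounds named here, the one step that changes the side chain, a number 4.8 percentage points lower from compound 1 to compound 3 (within the scatter), is within the scatter.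

Compound 4 `C[C@H](NC(=O)CN(c1nc(Cl)nc2[nH]cnc12)C1CC1)C(=O)O` is the next member; its change from compound 3 is methyl in place of 1-hydroxyethyl on a saturated chain carbon bound to an amide-type nitrogen and a carbonyl carbon. Going by the values given here, the only measured step touching this part of the molecule is the one from compound 1 to compound 3, and it was within the scatter despite a larger rearrangement of the side chain; compound 2, with a much longer side chain and an ester, also sits within the scatter of compound 3. The step of a number 0.9 percentage points higher from compound 3 to compound 4 (within the scatter) is therefore expected to stay within the scatter. Compound 4 is estimated at 31%, with a range of 18% to 44%.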

Compound 4, a percentage reported as activity, at one dose (the size of the read-out at that dose, not a potency): 44.6%
The estimate for compound 4 lay 13.6 percentage points below the measured number, outside the stated range (above it).
By their numbers in this assay, from the lowest: compounds 3, 2, 1 and 4 (each within the scatter of the next, the first and the last beyond it).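

In this assay, for the compounds shown here, methyl in place of 1-hydroxyethyl on a saturated chain carbon bound to an amide-type nitrogen and a carbonyl carbon gives a number 14.5 percentage points higher from compound 3 to compound 4 (beyond the scatter), the first step to clear the scatter, so the read-out does respond to a change at this place. The gain is only partly separated from the rest of the series, since a number 9.7 percentage points higher from compound 1 to compound 4 (within the scatter), and (1-carboxyethyl)amino therefore stands apart from (1-carboxy-2-hydroxypropyl)amino but not from 2-carboxypyrrolidin-1-yl. No evidence at hand bears on the reason for the step.

Open, going by these compounds, is whether the step follows the hydroxyl or the length of the chain: a hydroxymethyl or an ethyl group at this place would separate the two. Also open, on these data alone, is whether a single hydrogen there, or a longer chain such as propyl, would hold the higher number.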